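Aryl sulfonamide variation in a two-ring linker series

The compounds below may be only part of what the source reports. "The series", "measured", "known", "first", "only" and "open" are said of these compounds alone.

Compound 1 `O=C(NCc1ccc(CNS(=O)(=O)c2cccc(F)c2)cc1)c1ccc(F)cc1` gives 1000 nM in an assay on MDA-MB-231 cells for binding affinity to C-X-C chemokine receptor type 4 (Homo sapiens), read by fluorescence and microscopy, with stated times of 10 min and 30 min; a lower number here means that less compound is needed, a higher number that more compound is needed for the effect. Compound 2 `O=C(NCc1ccc(CNS(=O)(=O)c2ccccc2Cl)cc1)c1ccc(F)cc1` gives 1000 nM in this assay; the step of no change at the digits printed from compound 1 to compound 2 (within the scatter) is within the scatter, so compound 2 stands level with compound 1 on the numbers shown. Compound 3 `Cc1cccc(S(=O)(=O)NCc2ccc(CNC(=O)c3ccc(F)cc3)cc2)c1` carries the change (3-methylphenyl in place of 2-chlorophenyl on a sulfonyl sulfur). Among the compounds with values here, the only step that bears on it is the earlier swap of the aryl group on the same sulfonyl sulfur, no change at the digits printed from compound 1 to compound 2 (within the scatter), which moved nothing beyond the scatter; the step of no change at the digits printed from compound 2 to compound 3 (within the scatter) is therefore expected to be flat as well. Compound 3 is estimated at 1000 nM, with a range of 400 nM to 2500 nM.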

Compound 3, effective concentration (reported as EC, without a stated level of effect): 1 nM
Beside the measured number, compound 3's estimate is 1000-fold (3.00 log units) above it; measured number below the stated range.
By their numbers in this assay, from the lowest: compound 3; then compounds 1 and 2 (each within the scatter of the next).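

In this assay the aryl group on the sulfonyl sulfur is not a silent position after all: 3-methylphenyl in place of 2-chlorophenyl gives a 1000-fold lower number from compound 2 to compound 3 (3.00 log units; beyond the scatter). Methyl in place of fluoro on an aromatic carbon gives a 1000-fold lower number from compound 1 to compound 3 (3.00 log units; beyond the scatter), so a single substituent change on this ring can carry a large step, which the flat step between the first two compounds gave no sign of. No supporting data bear on the reason for these steps. Still open, on these data alone, is whether the methyl itself is required, or whether ethyl, methoxy or an amine in its place would hold the number.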